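Methyl on the amide nitrogen: expected effect on activity

The compounds below may be only part of what the source reports. "The series", "measured", "known", "first", "only" and "open" are said of these compounds alone.

Among the compounds with values here, compound 1 `CNC(=O)c1ccc(-c2cc(C(=O)N[C@H]3CCCNC3)c(NC(N)=O)s2)cc1` is the only member of this set with a number in a functional assay on HT-29 cells (Homo sapiens); a higher number here means that more compound is needed for the effect, a lower number that less compound is needed; there compound 1 gives 4300 nM. Compound 2 `NC(=O)Nc1sc(-c2ccccc2)cc1C(=O)NC1CCNCC1` belongs to the same set, but in this assay compound 2 gives "not determined" (no result reported), so it offers no point of reference. Compound 3 `CN(C)C(=O)c1ccc(-c2cc(C(=O)N[C@H]3CCCNC3)c(NC(N)=O)s2)cc1` is the one not yet measured. It differs from compound 1 by methyl in place of hydrogen on an amide-type nitrogen. Within the data shown here, no step between two measured compounds of this set is available, so the size of such a change cannot be read from the data themselves. Among the measured compounds shown here, the change brings in only one methyl group, and a step of about the usual scatter, if anything towards more compound being needed, is expected: a 1.3-fold higher number from compound 1 to compound 3 (0.11 log units; within the scatter). In this assay compound 3 is therefore expected to give about 5500 nM, with a range from 2000 nM to 15000 nM.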

Compound 3, half-maximal effective concentration: 320 nM
The estimate for compound 3 lay 17-fold (1.24 log units) above the measured number; measured number below the stated range.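

In this assay, exchanging the amide hydrogen of the methylcarbamoyl group for methyl, which gives the dimethylcarbamoyl group, produces a 13-fold lower number from compound 1 to compound 3 (1.13 log units; beyond the scatter) and so moves the read-out well beyond the scatter. Within the data shown here, the earlier compounds offered no step at all, so this pair is the first sign that the series is sensitive at this amide nitrogen, with a single added methyl group shifting the result towards less compound being needed.

From the compounds shown here alone, whether a longer chain such as ethyl on the same nitrogen, or a carboxylic acid in place of the whole dimethylcarbamoyl group, would extend or reverse this step remains open. A single pair also leaves open whether the methyl change would act alike on other members of the series. Nothing available on these compounds accounts for the size of the step.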